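Swapping the aryl ether in a cyclohexyl urea series

This account rests on a few compounds, and the source may have more. Where it says the series, first, only, none or still open, it means among the compounds named here.

compound 1 `O=C(Nc1cccc(C(F)(F)F)c1)N[C@H]1CC[C@H](Oc2ccc(Cl)cc2)CC1` — 2000 nM
compound 2 `O=C(Nc1ccccc1C(=O)O)N[C@H]1CC[C@@H](Oc2ccc(F)cc2)CC1` — > 20000 nM
compound 3 `COc1cccc(NC(=O)N[C@H]2CC[C@H](Oc3ccc(F)cc3)CC2)c1` — 14000 nM

In a functional assay on CRL2813 cells (Homo sapiens) for cytotoxicity, read by sulforhodamine B assay, with a stated time of 5 days (on this read-out lower numbers stand for stronger inhibition and higher numbers for weaker inhibition), compound 1 gives 2000 nM, the lowest of the two numbers recorded. Compound 3 gives 14000 nM, a gap beyond the scatter. Compound 2 reaches only a limit of the assay, > 20000 nM, so no number is known for it; this is the limit of > 20000 nM in this assay, at which 1 of the 3 values shown sits.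

Compound 4 `O=C(Nc1cccc(C(F)(F)F)c1)N[C@H]1CC[C@H](Oc2cccc(C(F)(F)F)c2)CC1` keeps the shared core of compound 1 and changes one place: 3-(trifluoromethyl)phenyl in place of 4-chlorophenyl on an oxygen on a saturated carbon. Among the measured compounds shown here, no pair of measured compounds shows this change, so its effect can only be guessed. The expected step from compound 1 to compound 4 in this assay is a 1.3-fold lower number from compound 1 to compound 4 (0.12 log units; within the scatter), small and within the scatter. Compound 4 is estimated at 1500 nM, between 500 nM and 5000 nM.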

Compound 4, half-maximal inhibitory concentration: 1300 nM
The estimate for compound 4 lay 1.2-fold (0.06 log units) above the measured number, within the range that was stated.
By their numbers in this assay, from the lowest: compounds 4 and 1 (each within the scatter of the next); then compound 3. At a limit, above all of these: compound 2.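

In this assay putting 3-(trifluoromethyl)phenyl in place of 4-chlorophenyl on the ether oxygen gives a 1.5-fold lower number from compound 1 to compound 4 (0.19 log units; within the scatter). Among the compounds shown here, the earlier compounds differ from one another in more than one place, so this is the first direct reading at this position, and here two different aryl groups cannot be told apart. Nothing measured here gives a reason for this step.

Open stays what an amine or a carboxylic acid in this place would do to the number. A plain phenyl group on the same oxygen is also still an open case.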